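Adding Fluoro to the Fused Ring of Compound 1

The source may hold more compounds than are shown below. What is called first, only, known or untested is meant among the compounds shown, and "the series" means these compounds.

Compound 1 `C#Cc1cc(-c2nc3ccccc3s2)ccc1N` gives 49 nM in a functional assay on MCF7 cells (Homo sapiens) for inhibition, with a stated time of 72 h (a higher number here means a weaker inhibitor of growth, a lower number a stronger inhibitor of growth), the lowest of the three numbers measured. Compound 2 `N#Cc1cc(-c2nc3ccc(F)cc3s2)ccc1N` gives 820 nM in this assay, and compound 3 `C[Si](C)(C)C#Cc1cc(-c2nc3ccc(F)cc3s2)ccc1N` gives 680 nM; both carry fluoro on the two-ring part of the core and a different group on the other ring, so each differs from compound 1 in two places. Among the measured compounds shown here, the only single-place step among them, a 1.2-fold lower number from compound 2 to compound 3 (0.08 log units; within the scatter), shows the two groups give numbers within the usual scatter. Compound 4 `C#Cc1cc(-c2nc3c(F)cccc3s2)ccc1N` is compound 1 with fluoro in place of hydrogen on an aromatic carbon. For the measured compounds named here, no measured step covers exactly this change; compounds 2 and 3 sit well above compound 1, but their second difference clouds the reading. A modest loss is therefore expected in this assay for compound 4, a 2.4-fold higher number from compound 1 to compound 4 (0.39 log units; beyond the scatter). Compound 4 is estimated at 120 nM, ranging from 30 nM to 500 nM.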

Compound 4, concentration for 50% growth inhibition: 110 nM
Estimate against measurement, compound 4: 1.1-fold (0.04 log units) above; the measured number falls inside the stated range.
By their numbers in this assay, from the lowest: compound 1; then compound 4; then compounds 3 and 2 (each within the scatter of the next).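

With nothing else changed, fluoro in place of hydrogen gives in this assay a 2.2-fold higher number from compound 1 to compound 4 (0.35 log units; beyond the scatter) and so a modest loss, which compounds 2 and 3 could not show cleanly. This position, ortho to a fused ring, therefore accepts fluoro with only a small change in the number. No available evidence bears on what lies behind this change. The compounds shown leave open whether fluoro on another carbon of this ring would give a similar step. They also leave open how a chloro or methoxy group would compare with fluoro on this same carbon.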